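The compounds below may be only part of what the source reports. "The series", "measured", "known", "first", "only" and "open" are said of these compounds alone.

Series notes. The shared core of compound 1 `CC(=O)N1CCN(CC(=O)N2CCN(c3cc4c(cc3F)c(=O)c(C(=O)O)cn4C3CC3)CC2)CC1` bears an acetyl on an amine nitrogen in a ring; compound 2 `O=C(O)c1cn(C2CC2)c2cc(N3CCN(C(=O)CN4CCN(Cc5ccccc5)CC4)CC3)c(F)cc2c1=O` bears a benzyl there, and compound 3 `O=C(O)c1cn(C2CC2)c2cc(N3CCN(C(=O)CN4CCN(C(c5ccccc5)c5ccccc5)CC4)CC3)c(F)cc2c1=O` adds a phenyl on the saturated chain carbon bound to that ring nitrogen. In an ADME assay on RAW264.7 cells (Mus musculus) for cytotoxicity, read by MTT assay, with a stated time of 72 h (on this read-out higher numbers stand for weaker inhibition and lower numbers for stronger inhibition), compound 1 gives 154000 nM, compound 2 gives 161000 nM and compound 3 gives 96600 nM. Compound 2 holds the highest of the three numbers, yet a 1.0-fold higher number from compound 1 to compound 2 (0.02 log units; within the scatter) and a 1.7-fold lower number from compound 2 to compound 3 (0.22 log units; within the scatter) both lie within the scatter, so no ordering among the three is secure. Compound 4 `Cc1cccc(N2CCN(CC(=O)N3CCN(c4cc5c(cc4F)c(=O)c(C(=O)O)cn5C4CC4)CC3)CC2)c1` is compound 2 with 3-methylphenyl in place of benzyl on an amine nitrogen in a ring. The two measured steps in this part of the series bear on it, and both were within the scatter; nothing measured here speaks for a step beyond the scatter in this assay, in either direction. For compound 4 the expected step is a 1.1-fold lower number from compound 2 to compound 4 (0.03 log units; within the scatter). Compound 4 is therefore estimated at 150000 nM in this assay, with a range from 75000 nM to 300000 nM.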

Compound 4, half-maximal inhibitory concentration: 154000 nM
For compound 4 the middle estimate is 1.0-fold (0.01 log units) below the measured one, within the range that was stated.
By their numbers in this assay, from the lowest: compounds 3, 1, 4 and 2 (each within the scatter of the next).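

In this assay, 3-methylphenyl in place of benzyl on the amine nitrogen in a ring gives a 1.0-fold lower number from compound 2 to compound 4 (0.02 log units; within the scatter), although the two groups have the same atoms, joined differently. Among the compounds shown here, with 3-methylphenyl in place of acetyl at the same nitrogen, the result is no change at the digits printed from compound 1 to compound 4 (within the scatter), so an aromatic ring bound directly to this nitrogen, absent from the earlier compounds, adds no step beyond the scatter to those seen with acetyl and benzyl. No available evidence accounts for this result.

From the compounds shown here alone, whether a group carrying a carboxylic acid or a primary amine on this ring nitrogen would give a step beyond the scatter remains open. So does the outcome with a longer chain ending in phenyl, such as 2-phenylethyl, at this nitrogen.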